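The compounds below may be only part of what the source reports. "The series", "measured", "known", "first", "only" and "open" are said of these compounds alone.

Measured in a functional assay on A549 cells (Homo sapiens) for antiproliferative activity, read by MTT assay, with a stated time of 24 h; on this read-out higher numbers stand for weaker inhibition and lower numbers for stronger inhibition:
- compound 1, `O=c1[nH]cc(S(=O)(=O)Nc2ccccc2-c2cn(-c3cccc(F)c3)nn2)c(=O)[nH]1`: 8130 nM
- compound 2, `Cc1cccc(-n2cc(-c3cccc(NS(=O)(=O)c4c[nH]c(=O)[nH]c4=O)c3)nn2)c1`: 3550 nM

Of these two numbers, compound 2 holds the lower one, which on this read-out means the stronger inhibition of cell growth. Compound 1 sits at a higher number, and the gap between the two is beyond the usual scatter of repeated measurements. Within the data shown here, the two compounds differ in more than one place, so no single structural step connects them; the values show only that compound 2 inhibits more strongly than compound 1 here, not which part of the structure is responsible.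

Compound 3, `O=c1[nH]cc(S(=O)(=O)Nc2cccc(-c3cn(-c4cccc(Cl)c4)nn3)c2)c(=O)[nH]1`, has not yet been measured. It differs from compound 2 in one place: chloro in place of methyl on an aromatic carbon. Among the measured compounds shown here, no measured pair shows what this exchange does on this scaffold, so there is nothing to anchor a direction. The expected step from compound 2 to compound 3 in this assay is therefore a 1.2-fold lower number from compound 2 to compound 3 (0.07 log units; within the scatter), a change small enough to fall within the scatter, in either direction. On that basis compound 3 is estimated at 3000 nM, with a range from 1200 nM to 8000 nM.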

Compound 3, half-maximal inhibitory concentration: 2430 nM
Compound 3: the middle estimate sits 1.2-fold (0.09 log units) above what was measured, and the stated range covers the measured number.
By their numbers in this assay, from the lowest: compounds 3 and 2 (each within the scatter of the next); then compound 1.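

Going from 3-methylphenyl to 3-chlorophenyl in this assay gives a 1.5-fold lower number from compound 2 to compound 3 (0.16 log units; within the scatter), so this pair is the first to show what this exchange does on this scaffold: on this read-out, compound 2 and compound 3 cannot be told apart. At this place, on an aromatic carbon and meta to a large group, chloro can therefore take the place of methyl with no difference in growth inhibition beyond what repeated measurements would produce. No measurement shown here speaks to why the two groups behave alike.

The compounds shown leave open how this position responds to groups unlike these two single-heavy-atom substituents, such as an amine, a carboxylic acid or a longer chain, any of which could give a much larger step than this one. They also leave open whether swapping methyl for chloro would be just as quiet elsewhere on this aromatic ring, since this single pair describes one position on one scaffold in one cell line.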